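The source may hold more compounds than are shown below. What is called first, only, known or untested is meant among the compounds shown, and "the series" means these compounds.

Measured in an assay on cells with melanin-concentrating hormone receptor 1 (Homo sapiens) as the target, read by radioligand binding; a higher number here means a weaker inhibitor, a lower number a stronger inhibitor:
compound 1 `Nc1ccc2cccc(OC3CCC3)c2n1` gives > 2000 nM, which is a limit of the assay and not a number.
compound 2 `COCC(C)Oc1cccc2ccc(N)nc12` gives 606 nM.
compound 3 `CC#CCCOc1cccc2ccc(N)nc12` gives > 2000 nM, again a limit of the assay rather than a number.

Compound 1 thus stands only at a limit in this assay, and two of the three values sit at the limit of > 2000 nM in this assay, at which 2 of the 3 values shown sit. Compound 4 `CCCCOc1cccc2ccc(N)nc12` differs from compound 1 by butyl in place of cyclobutyl on an oxygen on an aromatic ring. Among the compounds with values here, the steps that bear on this are an at least 3.3-fold lower number from compound 1 to compound 2 (0.51 log units; beyond the scatter) and a step that the two limits leave unreadable from compound 1 to compound 3. Compound 3, which carries a plain chain, sits at the limit, so no clear gain is visible for such chains. Compound 4, with its butyl chain, is therefore expected to stay close to the limit, at an estimated 3000 nM with a range from 1000 nM to 10000 nM. The expected step is a step that the limit leaves unreadable from compound 1 to compound 4.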

Compound 4, half-maximal inhibitory concentration: 789 nM
Compound 4: middle estimate off by 3.8-fold (0.58 log units), on the high side; the whole stated range lies above it.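

Changing cyclobutyl to butyl on the oxygen gives an at least 2.5-fold lower number from compound 1 to compound 4 (0.40 log units; beyond the scatter) in this assay, so at this position an open chain can be read where the four-membered ring could not. The end of the chain also counts, since ethyl in place of prop-1-yn-1-yl gives an at least 2.5-fold lower number from compound 3 to compound 4 (0.40 log units; beyond the scatter), while butyl in place of 1-(methoxymethyl)ethyl gives a 1.3-fold higher number from compound 2 to compound 4 (0.11 log units; within the scatter), so these two groups cannot be told apart. Compound 1 and compound 3 remain at a limit of the assay and not at a number: the limit of > 2000 nM in this assay, at which 2 of the 4 values shown sit. Still open, on these data alone, is whether a longer chain would take the number lower, and whether an amine or a carboxylic acid at the chain end would be tolerated.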